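The compounds below may be only part of what the source reports. "The series", "measured", "known", "first", "only" and "open" are said of these compounds alone.

Measured so far:
compound 1, `COc1ccc(CS(=O)(=O)/C=C/c2cc(F)c(F)cc2F)cc1N`, in a functional assay on K562 cells (Homo sapiens) for cytotoxicity, read by trypan blue exclusion, with a stated time of 96 h (a higher number here means a weaker inhibitor, a lower number a stronger inhibitor), gives 15000 nM
compound 2, `COC(=O)C(Nc1cc(CS(=O)(=O)/C=C/c2c(OC)cc(OC)cc2OC)ccc1OC)c1ccccc1`, gives 30 nM

Compound 2 stands lowest of the two numbers; its nearest neighbour is compound 1, whose number is higher by a gap well beyond the usual scatter. For the measured compounds named here, no pair of measured compounds differs in only one place, so no single step has been measured, and the gap between compound 1 and compound 2 spans several changes at once and cannot be read as one.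

Compound 3, `COc1cc(OC)c(/C=C/S(=O)(=O)Cc2ccc(OC)c(NC(C(=O)O)c3ccc(Cl)cc3)c2)c(OC)c1`, is the next compound. It differs from compound 2 in one place: carboxy(4-chlorophenyl)methyl in place of methoxycarbonyl)(benzyl on a nitrogen on an aromatic ring. The methoxycarbonyl)(benzyl group that leaves is replaced by carboxy(4-chlorophenyl)methyl on the nitrogen on the aromatic ring; the shared core otherwise stays as in compound 2. Going by the values given here, with no measured step of this kind, the expectation for compound 3 in this assay rests on compound 2 alone. A moderate step to a higher number is expected, though one that might also fall within the scatter. Compound 3 is estimated at 100 nM, within 25 nM to 600 nM. The step from compound 2 to compound 3 implied by this estimate is a 3.3-fold higher number from compound 2 to compound 3 (0.52 log units; beyond the scatter), expected rather than measured.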

Compound 3, half-maximal inhibitory concentration: 250 nM
Compound 3: middle estimate off by 2.5-fold (0.40 log units), on the low side; measured number inside the range.
By their numbers in this assay, from the lowest: compound 2; then compound 3; then compound 1.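

For the compounds shown here, on the nitrogen on an aromatic ring, carboxy(4-chlorophenyl)methyl in place of methoxycarbonyl)(benzyl gives an 8.3-fold higher number from compound 2 to compound 3 (0.92 log units; beyond the scatter) in this assay and so provides the first single-place step, showing that the number in this assay responds to a change at this position. The two groups match in heavy-atom count and each carries one six-membered aromatic ring, but the entering group brings a chlorine and a hydrogen-bond donor, and it has one hydrogen-bond acceptor where the leaving group has two, so this single step bundles more than one difference. Nothing available assigns a cause to the step or apportions it among those differences.

The compounds shown leave open how much of the step goes with the carboxylic acid in place of the methyl ester and how much goes with the chlorine on the phenyl ring, since neither difference appears alone. Also open, going by these compounds, is how a primary amide in place of the carboxylic acid, or a fluorine in place of the chlorine, would read at this position.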